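Para substituent swap on the anilinomethyl phthalimide series

The source may hold more compounds than are shown below. What is called first, only, known or untested is meant among the compounds shown, and "the series" means these compounds.

Numbers in hand from an assay on isolated protein for inhibition of ribosomal protein S6 kinase alpha-2 (Homo sapiens), read by fluorescence, with a stated time of 20 min, tested at 10 uM; a higher number here means more inhibition at the concentration tested (going by the name of the read-out), a lower number less inhibition:
- compound 1, `O=C1c2ccccc2C(=O)N1CNc1ccc(F)cc1`: 56.7%
- compound 2, `Cc1ccc(NCN2C(=O)c3ccccc3C2=O)cc1`: 54%
- compound 3, `CCc1ccc(NCN2C(=O)c3ccccc3C2=O)cc1`: 63%

The three compounds share one core and differ only in the group on the aromatic carbon of the six-membered carbon ring, para to the large group. Compound 3 gives the highest of the three numbers in this assay, but its lead is not a real one: the step of a number 6.3 percentage points higher from compound 1 to compound 3 (within the scatter) and the step of a number 9 percentage points higher from compound 2 to compound 3 (within the scatter) both sit within the scatter, as does the step of a number 2.7 percentage points lower from compound 1 to compound 2 (within the scatter). Fluoro, methyl and ethyl at this position therefore give numbers that cannot be told apart.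

Compound 4, `COc1ccc(NCN2C(=O)c3ccccc3C2=O)cc1`, is the next member. Change from compound 3: methoxy in place of ethyl on an aromatic carbon

Every measured step at this position, whether fluoro to methyl, fluoro to ethyl or methyl to ethyl, stayed within the scatter, and nothing measured here speaks for methoxy behaving differently. The step from compound 3 to compound 4 in this assay is therefore expected to be a number 5 percentage points lower from compound 3 to compound 4 (within the scatter), that is none beyond the scatter. Compound 4 is estimated at 58%, with a range of 45% to 70%.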

Compound 4, a percentage reported as inhibition, at one concentration (the size of the read-out at that concentration, not a potency): 97.2%
Estimate against measurement, compound 4: 39.2 percentage points below; measured number above the stated range.
By their numbers in this assay, from the lowest: compounds 2, 1 and 3 (each within the scatter of the next); then compound 4.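

In this assay, the aromatic carbon para to a large group turns out not to be indifferent to its substituent: methoxy gives a number 34.2 percentage points higher from compound 3 to compound 4 (beyond the scatter), alongside a number 43.2 percentage points higher from compound 2 to compound 4 (beyond the scatter) and a number 40.5 percentage points higher from compound 1 to compound 4 (beyond the scatter), so compound 4 stands apart from a group of three compounds that cannot be told apart. Size as counted in heavy atoms does not separate the two groups in the closest comparison, since ethyl and methoxy both have 2, while the counted differences are an oxygen in place of a carbon and 1 hydrogen-bond acceptor on methoxy against 0 on ethyl, though three comparisons of this kind cannot show that either difference is what matters. No measurement at hand offers an explanation for the jump at this position.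

Open, going by these compounds, is whether the high number belongs to methoxy alone or also extends to neighbouring groups at the same carbon, such as ethoxy, hydroxy or an amine. Also open, on these data alone, is how compound 4 ranks in potency, as a single-concentration percentage gives no potency and the number may lie close to the top of what this read-out can separate.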